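The source may report more compounds than this note shows. Statements on the series, on what has been measured and on what is new or still open speak of the compounds shown alone.

Measured in a functional assay on A549 cells (Homo sapiens) for antiproliferative activity, read by MTT assay, with a stated time of 24 h; a higher number here means a weaker inhibitor, a lower number a stronger inhibitor:
- compound 1 `Cc1cccc(NNC(=O)c2cccc(NS(=O)(=O)c3cnc(O)nc3O)c2)c1`: > 20000 nM
- compound 2 `Cc1cccc(NNC(=O)c2ccccc2NS(=O)(=O)c2cnc(O)nc2O)c1`: > 20000 nM
- compound 3 `O=C(NNC(=O)c1ccc(NS(=O)(=O)c2cnc(O)nc2O)cc1)c1ccc(F)cc1`: > 20000 nM

Compound 1 stands at the limit of > 20000 nM in this assay, at which 3 of the 3 values shown sit. That is a limit and not a number, so these results cannot rank the compounds against one another.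

Compound 4 `Cc1ccccc1C(=O)NNC(=O)c1cccc(NS(=O)(=O)c2cnc(O)nc2O)c1` changes one group of compound 1: (2-methylphenyl)carbonyl in place of 3-methylphenyl on an amine nitrogen. In words, (2-methylphenyl)carbonyl replaces 3-methylphenyl on an amine nitrogen, which brings in a carbonyl. Among the measured compounds shown here, no step between measured compounds is available to size this change. Compound 3 also carries a carbonyl on the matching nitrogen, and its > 20000 nM is again a limit.

In this assay, the expected step that the limit leaves unreadable from compound 1 to compound 4 is none beyond the scatter, with neither direction favoured. The likeliest expected outcome is another limit rather than a number. If a number is reported, the estimate for compound 4 is 25000 nM, with an expected range from 8000 nM to 60000 nM.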

Compound 4, half-maximal inhibitory concentration: 8010 nM
The estimate for compound 4 lay 3.1-fold (0.49 log units) above the measured number, within the range that was stated.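

In this assay, putting (2-methylphenyl)carbonyl in place of 3-methylphenyl on an amine nitrogen gives an at least 2.4-fold lower number from compound 1 to compound 4 (0.39 log units; beyond the scatter), so the group at this position can shift the read-out by more than the usual scatter. The step starts from a limit at compound 1, so it sets only a smallest size and not an exact one. Compound 4 is the only compound shown with a measured number rather than a limit: the limit of > 20000 nM in this assay, at which 3 of the 4 values shown sit.

The change brings in a carbonyl and also swaps 3-methylphenyl for a 2-methylphenyl ring, and the compounds shown cannot separate these two parts. From the compounds shown here alone, how a (3-methylphenyl)carbonyl group, an unsubstituted phenylcarbonyl group or a longer carbon chain would read at this nitrogen stays open.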